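Hydroxy to chloro on the shared core: an estimate

The compounds below may be only part of what the source reports. "The series", "measured", "known", "first", "only" and "open" are said of these compounds alone.

Measured so far in a functional assay on MCF7 cells (Homo sapiens) for inhibition, read by MTT assay, with a stated time of 72 h; on this read-out lower numbers stand for stronger inhibition and higher numbers for weaker inhibition:
compound 1, `COc1cc(OC)c(OC)cc1/C=C/C(=O)c1ccc(O)cc1`: 182000 nM
compound 2, `COc1cc(C(=O)/C=C/c2cc(OC)c(OC)cc2OC)ccc1O`: 95500 nM
compound 3, `COc1cc(OC)c(OC)cc1/C=C/C(=O)c1cccc(C(F)(F)F)c1`: > 150000 nM, which is a limit of the assay

Compound 1 and compound 2 differ by methoxy in place of hydrogen on an aromatic carbon and sit within the scatter of each other, a 1.9-fold lower number from compound 1 to compound 2 (0.28 log units; within the scatter). For compound 3 only the limit of > 150000 nM in this assay, at which 1 of the 3 values shown sits, is known. Compound 4, `COc1cc(OC)c(OC)cc1/C=C/C(=O)c1ccc(Cl)cc1`, differs from compound 1 by chloro in place of hydroxy on an aromatic carbon. Among the compounds with values here, no measured step bears on this change; the single step known, from compound 1 to compound 2, stays within the scatter and concerns another group. The step from compound 1 to compound 4 is therefore expected to be small, a 1.1-fold lower number from compound 1 to compound 4 (0.06 log units; within the scatter), with a wide range and a fair chance that this assay returns only a limit. Compound 4 is estimated at 160000 nM, between 50000 nM and 500000 nM.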

Compound 4, half-maximal inhibitory concentration: 29500 nM
The estimate for compound 4 lay 5.4-fold (0.73 log units) above the measured number, and the stated range ends above it.
By their numbers in this assay, from the lowest: compound 4; then compounds 2 and 1 (each within the scatter of the next).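

In this assay, within the data shown here, the 4-hydroxyphenyl to 4-chlorophenyl change gives the first step beyond the scatter (a 6.2-fold lower number from compound 1 to compound 4 (0.79 log units; beyond the scatter)). This position, para to a large group, therefore responds to the group placed on it, which the within-scatter methoxy step could not show. Nothing measured here accounts for the size of this step. Still open, as far as these compounds go, is whether an amine or a carboxylic acid at this position would give a lower or a higher number than chloro. Compound 3 remains a limit and gives no step: the limit of > 150000 nM in this assay, at which 1 of the 4 values shown sits.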